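The source may hold more compounds than are shown below. What is called first, only, known or untested is meant among the compounds shown, and "the series" means these compounds.

Measured so far:
compound 1, `O=C(O)CCCN1Cc2ccc(NC(=O)CCCC3CCNCC3)cc2C1=O`: 51000 nM
compound 2, `O=C(O)CN1Cc2ccc(NC(=O)c3ccc(C4CCNCC4)cc3)cc2C1=O`: 24000 nM

In a functional assay on a cell-free system (Platelet, plasma, Homo sapiens) for inhibition (a lower number here means a stronger inhibitor, a higher number a weaker inhibitor), compound 2 gives 24000 nM, the lower of the two numbers. Compound 1 gives 51000 nM, and the gap between the two lies beyond the usual scatter, so compound 2 is the stronger inhibitor of this pair. Compound 3, `CC(CC(=O)O)N1Cc2ccc(NC(=O)c3ccc(C4CCNCC4)cc3)cc2C1=O`, has not yet been measured in this assay. It differs from compound 2 in one place: 1-(carboxymethyl)ethyl in place of carboxymethyl on an amide-type nitrogen in a ring. Within the data shown here, no measured pair shows the effect of such a change, so the size of the step cannot be read from the present numbers; the change is a small one in count of atoms. The step from compound 2 to compound 3 is expected to be about a 1.1-fold lower number from compound 2 to compound 3 (0.04 log units; within the scatter), with no clear direction beyond the scatter. Compound 3 is therefore estimated at 22000 nM, with a range from 8000 nM to 60000 nM.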

Compound 3, half-maximal inhibitory concentration: 6200 nM
Compound 3: middle estimate off by 3.5-fold (0.55 log units), on the high side; measured number below the stated range.
By their numbers in this assay, from the lowest: compound 3; then compound 2; then compound 1.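

On the amide-type nitrogen in a ring, the group carrying the carboxylic acid affects the result in this assay: 1-(carboxymethyl)ethyl in place of carboxymethyl gives a 3.9-fold lower number from compound 2 to compound 3 (0.59 log units; beyond the scatter). Among these compounds, this is the first one-place step, and it shows that a small enlargement of this group, with the same counts of hydrogen-bond donors and acceptors, can lower the number. Nothing available bears on why the number moves.

The compounds shown do not separate the contribution of the extra chain carbon from that of the branch, a question the unbranched 2-carboxyethyl group would address. Also open, as far as these compounds go, are how a larger branch such as phenyl would behave and whether a methyl ester could stand in place of the carboxylic acid.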